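This account rests on a few compounds, and the source may have more. Where it says the series, first, only, none or still open, it means among the compounds named here.

Three compounds share one core. Compound 1 `O=C1NC(=S)/C(=C/c2ccc(Cl)cc2)S1`, compound 2 `O=C1NC(=S)/C(=C/c2ccccc2Br)S1` and compound 3 `O=C1NC(=S)/C(=C/c2ccccc2Cl)S1` were tested in a functional assay on NCI-H292 cells (Homo sapiens) for cytotoxicity, read by MTT assay, with a stated time of 72 h, tested at 10 ug/mL; on this read-out higher numbers stand for more inhibition of growth at the one concentration tested and lower numbers for less inhibition of growth. There compound 1 gives 41.4%, compound 2 gives 36.9% and compound 3 gives 45%. Compound 3 holds the highest of the three numbers, yet its gaps to the other two lie within the scatter. Going by the values given here, the only single-change step among them, a number 8.1 percentage points higher from compound 2 to compound 3 (within the scatter), also stays within the scatter. Compound 4 `O=C1NC(=S)/C(=C/c2ccc(Cl)cc2Cl)S1` differs from compound 3 by chloro in place of hydrogen on an aromatic carbon. Among the compounds with values here, no measured step adds a chloro group; compound 1 and compound 3 each carry one chloro group, and their numbers agree within the scatter. For compound 4 the expected step is therefore no change at the digits printed from compound 3 to compound 4 (within the scatter), none beyond the scatter. Compound 4 is estimated at 45%, within 30% to 60%.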

Compound 4, percent growth inhibition at one concentration: 38.4%
Beside the measured number, compound 4's estimate is 6.6 percentage points above it, within the range that was stated.
By their numbers in this assay, from the lowest: compounds 2, 4, 1 and 3 (each within the scatter of the next).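

Seen from either compound with one chloro group, adding a second gives a number 6.6 percentage points lower from compound 3 to compound 4 (within the scatter) in this assay, and a number 3 percentage points lower from compound 1 to compound 4 (within the scatter). Chloro in place of hydrogen at this position, para to a group of 8 heavy atoms, therefore gives a step that stays within the scatter, as does the second chloro group reached from compound 1. Nothing available gives a measured property that could account for these numbers. On these data alone, whether an amine or a carboxylic acid at this position would give a step beyond the scatter remains open.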